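The compounds below may be only part of what the source reports. "The series", "measured", "known", "first", "only" and "open" are said of these compounds alone.

Notes on the series. In a functional assay on EA.hy 926 cells (Homo sapiens) for cytotoxicity, read by MTT assay, with stated times of 24 h and 12 h, tested at 100 uM (on this read-out lower numbers stand for a weaker effect and higher numbers for a stronger effect at the one concentration tested), compound 1 `Cc1nc(C)c(C(=O)Oc2ccccc2/C=C/C(=O)O)nc1C` gives 80.1%, the highest of the three numbers: compound 2 `COc1ccc(OC(=O)c2nc(C)c(C)nc2C)c(/C=C/C(=O)O)c1` gives 79.2%, a step of a number 0.9 percentage points lower from compound 1 to compound 2 (within the scatter), and compound 3 `Cc1nc(C)c(C(=O)Oc2ccc(Cl)cc2/C=C/C(=O)O)nc1C` gives 52.2%, a step of a number 27.9 percentage points lower from compound 1 to compound 3 (beyond the scatter); between the two, a number 27 percentage points lower from compound 2 to compound 3 (beyond the scatter). Compound 4 `CCOC(=O)/C=C/c1ccccc1OC(=O)c1nc(C)c(C)nc1C` differs from compound 1 by ethyl in place of hydrogen on an oxygen next to a carbonyl group. Within the data shown here, none of the measured steps bears on this change: all three are substitutions on an aromatic carbon, and no pair differing on an oxygen next to a carbonyl group has been measured. With no guide, the expected step is a number 4.1 percentage points lower from compound 1 to compound 4 (within the scatter), none beyond the scatter. For compound 4 the estimate in this assay is 76%, range 58% to 90%.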

Compound 4, a percentage reported as activity, at one concentration (the size of the read-out at that concentration, not a potency): 40.9%
The estimate for compound 4 lay 35.1 percentage points above the measured number; the measured number lies below the stated range.
By their numbers in this assay, from the lowest: compound 4; then compound 3; then compounds 2 and 1 (each within the scatter of the next).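

Ethoxycarbonyl in place of carboxy, a change away from the aromatic carbons, gives in this assay a number 39.2 percentage points lower from compound 1 to compound 4 (beyond the scatter). The result shows that this position is not neutral here: ethyl on the oxygen next to a carbonyl group moves the read-out beyond the scatter, whereas methoxy on an aromatic carbon in compound 2 did not. No available evidence bears on what lies behind this step.

Going by these compounds, whether the step is specific to ethyl remains open; methyl, a longer chain such as butyl, or an amide in place of the carboxylic acid would test this.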